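Dithioester heptanoic acids and anilides on Bel-7402 cells

The source may report more compounds than this note shows. Statements on the series, on what has been measured and on what is new or still open speak of the compounds shown alone.

Measured compounds:
compound 1 `CC(=O)SCCC(CCCCC(=O)O)SC(C)=O` gives 8.35%
compound 2 `O=C(O)CCCCC(CCSC(=O)c1ccccc1)SC(=O)c1ccccc1` gives 81%
compound 3 `CC(=O)SCCC(CCCCC(=O)Nc1ccccc1)SC(C)=O` gives 14.1%

The three measured compounds were run in a functional assay on Bel-7402 cells (Homo sapiens) for inhibition, read by MTT assay, with a stated time of 24 h, tested at 100 ug/mL; a lower number here means less inhibition of growth, a higher number more inhibition of growth at the concentration tested. Compound 1 and compound 3 share one core and differ only by anilino in place of hydroxy on a carbonyl carbon; the step is a number 5.8 percentage points higher from compound 1 to compound 3 (within the scatter), so the two values cannot be told apart. Compound 2 carries a different core, with benzoyl groups on both sulfur atoms; the difference between the core of compound 1 and the core of compound 2 is not broken down here. In this assay compound 2 stands highest of the three, and its distance to compound 3 and to compound 1 is beyond the scatter in both cases.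

Compound 4 `O=C(CCCCC(CCSC(=O)c1ccccc1)SC(=O)c1ccccc1)Nc1ccccc1` has not yet been measured. It is derived from compound 2 by anilino in place of hydroxy on a carbonyl carbon, the same change that leads from compound 1 to compound 3, at the same place on the chain. That earlier step was within the scatter. On this basis the step from compound 2 to compound 4 is expected to be small as well, estimated at a number 2 percentage points higher from compound 2 to compound 4 (within the scatter), because compound 1 to compound 3 gave a number 5.8 percentage points higher from compound 1 to compound 3 (within the scatter). Compound 4 is therefore estimated at 83% in this assay, with a range from 66% to 95%, the upper end kept in check by the already high reading of compound 2, which gives 81%.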

Compound 4, percent growth inhibition at one concentration: "not active" (no number reported)
For compound 4 the study gives words and no number, and the estimate cannot be compared.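

In this assay, within the data shown here, compound 4 is reported as "not active" without a number, so no step from compound 2 to compound 4 can be read. Nothing shown offers an explanation for this result. The compounds shown leave open how far compound 4 lies from compound 2, and whether anilino in place of hydroxy on a carbonyl carbon acts alike on the core of compound 1 and the core of compound 2.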